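The source may hold more compounds than are shown below. What is called first, only, known or untested is meant among the compounds shown, and "the series" means these compounds.

In a functional assay on NCI-H1581 cells (Homo sapiens) for antiproliferative activity, read by CCK-8 assay, with a stated time of 72 h (on this read-out lower numbers stand for stronger inhibition and higher numbers for weaker inhibition), compound 1 `CCN1CCN(c2ccc(C(=O)Nc3n[nH]c4nc(-c5c(Cl)c(OC)cc(OC)c5Cl)ccc34)cc2)CC1` gives 0.7 nM while compound 3 `COc1cc(OC)c(Cl)c(-c2ccc3c(NC(=O)c4ccc(N(C)C)cc4)n[nH]c3n2)c1Cl` gives 294 nM as the higher of these two numbers. Compound 2 `COc1cc(OC)c(Cl)c(-c2ccc3c(NC(=O)c4ccccc4)n[nH]c3n2)c1Cl` has only a limit (> 1000 nM) and no number. Compound 4 `COc1cc(OC)c(Cl)c(-c2ccc3c(NC(=O)c4ccc(N(C)CCN(C)C)cc4)n[nH]c3n2)c1Cl` differs from compound 3 by (dimethylamino)methyl in place of hydrogen on a saturated chain carbon bound to a nitrogen on an aromatic ring (dimethylamino becomes (2-(dimethylamino)ethyl)(methyl)amino). Among the measured compounds shown here, two measured steps bear on this change: an at least 3.4-fold lower number from compound 2 to compound 3 (0.53 log units; beyond the scatter) (at least modest) and a 420-fold higher number from compound 1 to compound 3 (2.62 log units; beyond the scatter) (large). Neither tests this chain directly, but compound 1 shows that a larger amine-bearing group than dimethylamino can sit at a much lower number, so a moderate fall is expected. The expected change is a 12-fold lower number from compound 3 to compound 4 (1.07 log units; beyond the scatter) (an estimate). Compound 4 is estimated at 25 nM (range 3 nM to 200 nM).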

Compound 4, half-maximal inhibitory concentration: 11 nM
Compound 4: middle estimate off by 2.3-fold (0.36 log units), on the high side, within the range that was stated.
By their numbers in this assay, from the lowest: compound 1; then compound 4; then compound 3. At a limit, above all of these: compound 2.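

In this assay, (dimethylamino)methyl in place of hydrogen on this saturated chain carbon gives a 27-fold lower number from compound 3 to compound 4 (1.43 log units; beyond the scatter), so the position takes the added amine-bearing chain with a large change. Compound 2 has only a limit: the limit of > 1000 nM in this assay, at which 1 of the 4 values shown sits. The whole (2-(dimethylamino)ethyl)(methyl)amino group gives an at least 90-fold lower number from compound 2 to compound 4 (1.95 log units; beyond the scatter), yet exchanging 4-ethylpiperazin-1-yl for it gives a 16-fold higher number from compound 1 to compound 4 (1.20 log units; beyond the scatter), so this open chain stays short of the ring-bearing group. The compounds shown leave open how a longer chain, a chain ending in a hydroxyl group or a piperazine without the ethyl group would compare.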